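A few compounds are considered here, and "the series" means these few. Any claim that something is new, unique, unknown or untested is made for them only; others in the source may bear on it.

Three compounds sharing one core were measured in an assay on isolated protein for binding affinity to leukotriene B4 receptor (Homo sapiens), tested at 0.1 uM; a lower number here means less inhibition, a higher number more inhibition at the concentration tested (going by the name of the read-out). Compound 1, `CCc1cc(C(C)=O)c(O)cc1OCCCC(C)(C)C#N`, gives 13%. Compound 2, `CCc1cc(C(C)=O)c(O)cc1OCCCCC(C)(C)C#N`, gives 5%. Compound 3, `CCc1cc(C(C)=O)c(O)cc1OCCCCCCC(C)(C)C#N`, gives 11%. Each pair among them lies within the usual scatter: a number 8 percentage points lower from compound 1 to compound 2 (within the scatter), a number 2 percentage points lower from compound 1 to compound 3 (within the scatter) and a number 6 percentage points higher from compound 2 to compound 3 (within the scatter). On this evidence the three numbers in this assay are level with one another.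

Compound 4, `CCc1cc(C(C)=O)c(O)cc1OCCCCCCCC(C)(C)C#N`, is not yet measured. It differs from compound 3 by 2-cyano-2-methylpropyl in place of 1-cyano-1-methylethyl on a saturated chain carbon, six bonds along the chain from an oxygen on an aromatic ring. The change from compound 1 to compound 2 is 2-cyano-2-methylpropyl in place of 1-cyano-1-methylethyl on a saturated chain carbon, three bonds along the chain from an oxygen on an aromatic ring, and it made the step of a number 8 percentage points lower from compound 1 to compound 2 (within the scatter). The cores of compound 1 and compound 3 differ by 4-cyano-4-methylpentyl in place of 1-cyano-1-methylethyl on a saturated chain carbon, three bonds along the chain from an oxygen on an aromatic ring. The two places are not the same word for word: in compound 1 the group sits three bonds along the chain from an oxygen on an aromatic ring, in compound 3 six bonds along the chain from an oxygen on an aromatic ring, so the change from compound 3 to compound 4 is the same kind of change, not the same.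

For compound 4 a step of a number 3 percentage points lower from compound 3 to compound 4 (within the scatter) in this assay is expected, beside the earlier a number 8 percentage points lower from compound 1 to compound 2 (within the scatter), which rests on that step alone and on the fact that all three measured numbers sit within the scatter of one another. Compound 4 is therefore estimated at 8%, with a range from 0% to 20%.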

Compound 4, a percentage reported as inhibition, at one concentration (the size of the read-out at that concentration, not a potency): 6%
The estimate for compound 4 lay 2 percentage points above the measured number; measured number inside the range.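

In this assay, 2-cyano-2-methylpropyl in place of 1-cyano-1-methylethyl gives a number 5 percentage points lower from compound 3 to compound 4 (within the scatter), and this step agrees with the one seen earlier for the same change on the shorter chain: the same change on two cores in this assay, a number 8 percentage points lower (within the scatter) from compound 1 to compound 2 and a number 5 percentage points lower (within the scatter) from compound 3 to compound 4, 3 percentage points apart, within the scatter of two such steps

The larger replacement, 4-cyano-4-methylpentyl in place of 1-cyano-1-methylethyl, gives a number 1 percentage points higher from compound 2 to compound 4 (within the scatter), and it agrees in the same way with its earlier counterpart: the same change on two cores in this assay, a number 2 percentage points lower (within the scatter) from compound 1 to compound 3 and a number 1 percentage points higher (within the scatter) from compound 2 to compound 4, 3 percentage points apart, within the scatter of two such steps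

This shows that, across these compounds, lengthening the chain carries over from one core to another only as a step that stays within the scatter; it does not show that the change has any real effect on the read-out that could be transferred, since none of the steps compared stands clear of the scatter, and matching steps of this size say little about a larger series.

Going by these compounds, all four compounds share the same substituted core and end their chain in the same nitrile, so what a carboxylic acid, an amide or a tetrazole at the chain end would do remains open, as does the result of a still longer chain. Readings at a single concentration also leave open how these compounds would compare at any other concentration.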